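The source may hold more compounds than are shown below. What is called first, only, known or untested is meant among the compounds shown, and "the series" means these compounds.

Compound 1 `CCCCN(Cc1ccc(C(=O)NO)cc1)c1ncc(-c2ccc(C)cc2)s1` carries a butyl group on the nitrogen of its core and, in a functional assay on PC-3 cells (Homo sapiens) for antiproliferative activity, read by MTT assay, with a stated time of 48 h (on this read-out higher numbers stand for weaker inhibition of growth and lower numbers for stronger inhibition of growth), compound 1 gives 6410 nM. Compound 2 `Cc1ccc(-c2cnc(N(Cc3ccccc3)Cc3ccc(C(=O)NO)cc3)s2)cc1` differs from it only in the group on the saturated chain carbon bound to that nitrogen; in this assay compound 2 gives 10400 nM. Among the measured compounds shown here, the one step measured so far, a 1.6-fold higher number from compound 1 to compound 2 (0.21 log units; within the scatter), does not separate the two compounds, so compound 1 stands among two numbers that cannot be told apart on these data.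

Compound 3 `Cc1ccc(-c2cnc(N(Cc3ccc(C(=O)NO)cc3)C(C)C)s2)cc1` has not yet been measured. Against compound 1 the difference is isopropyl in place of butyl on a nitrogen on an aromatic ring. For the measured compounds named here, the only measured step touches a different place, the saturated chain carbon, and was itself within the scatter; nothing measured here speaks to a change on the nitrogen. Going by the values given here, with a butyl swapped for an isopropyl and no step in hand that bears on that position, the expectation for compound 3 is a number close to that of compound 1, a step of a 1.0-fold higher number from compound 1 to compound 3 (0.01 log units; within the scatter) that stays within the scatter. Compound 3 is therefore estimated at 6500 nM, with a likely range from 2800 nM to 15000 nM.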

Compound 3, concentration for 50% growth inhibition: 1150 nM
Compound 3: the middle estimate sits 5.7-fold (0.75 log units) above what was measured; measured number below the stated range.
By their numbers in this assay, from the lowest: compound 3; then compounds 1 and 2 (each within the scatter of the next).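

Changing the group on the nitrogen of the core does shift the number in this assay: isopropyl in place of butyl gives a 5.6-fold lower number from compound 1 to compound 3 (0.75 log units; beyond the scatter), and isopropyl in place of benzyl gives a 9.0-fold lower number from compound 2 to compound 3 (0.96 log units; beyond the scatter), both beyond the scatter. Butyl and benzyl could not be told apart, so the earlier pair made this position look insensitive to its substituent, whereas isopropyl, with 3 carbon atoms against the 4 of butyl, stands clearly apart from both. The data offer no measurement that explains this difference.

Going by these compounds, what remains open is whether the shorter chain or the branching matters here, since a straight propyl group, with the same carbon count as isopropyl, would help separate those two features. It is also unclear how far the trend extends, for example whether a cyclopropyl or tert-butyl group on this nitrogen would give a number close to that of compound 3 or one closer to those of compounds 1 and 2.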